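This account rests on a few compounds, and the source may have more. Where it says the series, first, only, none or still open, it means among the compounds named here.

Compound 2 `COC(=O)CNc1c(C(=O)NCc2ccc(F)cc2)nc(Br)c2cccnc12`: 1000 nM
Compound 1 `N[C@H]1CC[C@H](Nc2c(C(=O)NCc3cccc(C(F)(F)F)c3)nc(Br)c3cccnc23)CC1`: "not determined" (no result reported)
Compound 3 `CN(C)c1ccc(CNC(=O)c2nc(Br)c3cccnc3c2N[C@H]2CC[C@H](N)CC2)cc1`: "not determined" (no result reported)

In a functional assay on SK-BR-3 cells (Homo sapiens) for cytotoxicity, read by MTT assay, with a stated time of 72 h (a lower number here means a stronger inhibitor, a higher number a weaker inhibitor), compound 2 gives 1000 nM. For the measured compounds named here, this is the only number in the set; in this assay compound 1 gives "not determined" (no result reported) and compound 3 gives "not determined" (no result reported), so nothing can be compared against compound 2. Compound 4 `CN(C)CCCNc1c(C(=O)NCc2ccc(F)cc2)nc(Br)c2cccnc12` differs from compound 2 in one place: 2-(dimethylamino)ethyl in place of methoxycarbonyl on a saturated chain carbon bound to a nitrogen on an aromatic ring. Going by the values given here, with no measured pair to learn from, the size of this step can only be guessed; the expectation is a change no larger than the ordinary scatter of this assay, in either direction. Compound 4 is therefore expected to come out near compound 2, with the step from compound 2 to compound 4 estimated as a 1.3-fold lower number from compound 2 to compound 4 (0.10 log units; within the scatter). The estimate for compound 4 is 800 nM, within a range from 200 nM to 3000 nM.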

Compound 4, half-maximal inhibitory concentration: 1000 nM
Estimate against measurement, compound 4: 1.3-fold (0.10 log units) below; measured number inside the range.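

In this assay there is no change at the digits printed from compound 2 to compound 4 (within the scatter), the first comparison this set allows. At this place, on a saturated chain carbon bound to a nitrogen on an aromatic ring, the assay does not tell 2-(dimethylamino)ethyl from methoxycarbonyl, even though the two groups share neither their atoms nor their heavy-atom count. No measurement here offers an explanation for this result. The compounds shown leave open whether a carboxylic acid or a longer chain at the same place would move the number beyond the scatter.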